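Compound 3 against a series that sits at the limit

The source may report more compounds than this note shows. Statements on the series, on what has been measured and on what is new or still open speak of the compounds shown alone.

Compound 2 (`Cc1ccc(S(=O)(=O)N[C@@H](CC(=O)NC(C)(C)C)C(=O)NCCNC(=O)c2ccc(F)cc2)cc1`) gives > 11100 nM in an ADME assay on Karpas-1106P cells (Homo sapiens) for cytotoxicity (on this read-out higher numbers stand for an effect only at larger amounts of compound and lower numbers for an effect already at smaller amounts), which is a limit of the assay and not a number. Compound 1 (`Cc1ccc(S(=O)(=O)N[C@@H](CC(=O)NC(C)(C)C)C(=O)NCCNC(=O)c2cccc(O)c2)cc1`) gives > 11100 nM in this assay, and this is also only a limit. The record so far is therefore (the limit of > 11100 nM in this assay, at which 2 of the 2 values shown sit).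

Compound 3 (`COc1cc(OC)cc(C(=O)NCCNC(=O)[C@H](CC(=O)NC(C)(C)C)NS(=O)(=O)c2ccc(C)cc2)c1`) differs from compound 2 by one change: 3,5-dimethoxyphenyl in place of 4-fluorophenyl on a carbonyl carbon. It carries 3,5-dimethoxyphenyl in place of 4-fluorophenyl on a carbonyl carbon, and the rest of the structure stays the same.

Among the compounds with values here, the only measured step at this place is a step that the two limits leave unreadable from compound 1 to compound 2. It offers no size to carry over and no direction, so the expectation rests on the two limits alone. No step beyond the scatter is expected in this assay, and another report as a limit is the likeliest outcome. The estimated step is a step that the limit leaves unreadable from compound 2 to compound 3, with no direction expected in it.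

For compound 3 the estimate is 15000 nM, with an expected range from 7000 nM to 30000 nM.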

Compound 3, half-maximal effective concentration: > 11100 nM
Compound 3: no number, only a limit; the forecaster's own chance of this, stated with the estimate: 85%; the middle value is on the limit's open side.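

No new step can be read: in this assay compound 3 gives > 11100 nM, which is a limit and not a number, and its steps from compound 1 and compound 2 stay unreadable. The compounds shown leave open whether any group on this carbonyl carbon gives a readable number in this assay, since the record stands at: the limit of > 11100 nM in this assay, at which 3 of the 3 values shown sit.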